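The compounds below may be only part of what the source reports. "The series", "measured", "known", "first", "only" and "open" are said of these compounds alone.

Compound 1, `CC1CCN(C2CCN(S(=O)(=O)c3ccc(C#N)cc3)CC2)CC1`, gives 2800 nM in a functional assay on DLD-1 cells (Homo sapiens) for antiproliferative activity, read by CellTiter-Glo, with a stated time of 72 h; on this read-out lower numbers stand for stronger inhibition and higher numbers for weaker inhibition.
Compound 2, `COc1ccc(OC)c(S(=O)(=O)N2CCC(N3CCC(C)CC3)CC2)c1`, gives 4.5 nM in this assay.

Of the two measured compounds, compound 2 stands lowest in this assay; compound 1 sits far above it, a gap well beyond the scatter, so the two aryl groups on the shared core behave very differently. The step under study leads from compound 2 to the unmeasured compound 3, `COc1cccc(S(=O)(=O)N2CCC(N3CCC(C)CC3)CC2)c1`, a change counted as hydrogen in place of methoxy on an aromatic carbon. Within the data shown here, no measured pair traces this exact change, so what remains of the dimethoxy pattern after one methoxy leaves can only be guessed from compound 2 against compound 1. Because compound 2 shows 4.5 nM while compound 1 shows 2800 nM, the aryl substitution clearly matters, and the expected step of an 8.9-fold higher number from compound 2 to compound 3 (0.95 log units; beyond the scatter) is toward a higher number, probably beyond the scatter. Compound 3 is therefore estimated at 40 nM, within 8 nM to 250 nM.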

Compound 3, half-maximal inhibitory concentration: > 5000 nM
Compound 3: a limit, no number (the forecaster's own chance of this, stated with the estimate: 2%); at least 120-fold (2.09 log units) between middle value and limit.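

In this assay, among these compounds, the methoxy ortho to a large group proves decisive, something no earlier pair could show: hydrogen in its place gives an at least 1100-fold higher number from compound 2 to compound 3 (3.04 log units; beyond the scatter). The methoxy left on the ring of compound 3 therefore does not preserve the low number of compound 2. The reading for compound 3 is a limit of the assay, not a number: the limit of > 5000 nM in this assay, at which 1 of the 3 values shown sits.

The other new comparison, an at least 1.7-fold higher number from compound 1 to compound 3 (0.25 log units; that floor lies within the scatter), has a floor within the scatter and so sets no order between the two aryl groups. The compounds shown leave open whether a chlorine, a methyl or an ethoxy on that aromatic carbon would hold the number of compound 2. They also leave open what removing the other methoxy alone would do, with the methoxy ortho to a large group kept in place.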